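The compounds below may be only part of what the source reports. "The series", "measured", "known", "first", "only" and "open" are said of these compounds alone.

Compound 1 `O=C(Nc1ccc(Cl)cc1)c1cc([N+](=O)[O-])ccc1Cl`; in an ADME assay on HepG2 cells (Homo sapiens) for inhibition, with a stated time of 72 h (on this read-out lower numbers stand for an effect already at smaller amounts and higher numbers for an effect only at larger amounts of compound), compound 1 gives > 25000 nM, a limit of the assay.
Compound 2 `C/C=C/C(=O)Nc1cccc(-c2nc3ccccc3s2)c1`; in this assay compound 2 gives > 25000 nM, a limit of the assay.
Compound 3 `O=C(CCl)Nc1cccc(-c2nc3ccccc3s2)c1`; in this assay compound 3 gives 16000 nM.

For the measured compounds named here, compound 3 therefore holds the only number in this set; the other two entries sit at the limit of > 25000 nM in this assay, at which 2 of the 3 values shown sit, and give no number. Going by the values given here, the single measured step in this set is an at least 1.5-fold lower number from compound 2 to compound 3 (0.19 log units; that floor lies within the scatter), and it rests on a floor that lies within the scatter, so it shows no clear gain and leaves open how far below the limit compound 3 really sits.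

Compound 4 `O=C(Nc1cccc(-c2nc3ccccc3s2)c1)c1cccnc1Cl` differs from compound 3 in one place: 2-chloropyridin-3-yl in place of chloromethyl on a carbonyl carbon. Among the compounds with values here, no measured step covers an exchange of chloromethyl for an aromatic ring on the carbonyl carbon, and the step from compound 2 to compound 3 concerns a different pair of groups on that carbon. With two of three entries at the limit, the expectation for compound 4 is a number close to or beyond the limit, with a fair chance that only a limit is reported. Compound 4 is estimated at 30000 nM, in the range 10000 nM to 100000 nM, which corresponds to an expected step of a 1.9-fold higher number from compound 3 to compound 4 (0.27 log units; within the scatter).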

Compound 4, half-maximal effective concentration: > 25000 nM
Compound 4: only a limit was reported; the forecaster's own chance of this, stated with the estimate: 60%; the middle value lies beyond the limit too.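

For the compounds shown here, on the carbonyl carbon whose other neighbour is the amide-type nitrogen, 2-chloropyridin-3-yl in place of chloromethyl gives in this assay an at least 1.5-fold higher number from compound 3 to compound 4 (0.19 log units; that floor lies within the scatter); this is the first read-out for an aromatic ring at this place, and it shows no clear change, although the true size of the step remains hidden behind the limit. The step from compound 2 to compound 4 cannot be read, as both entries are limits, so prop-1-en-1-yl and 2-chloropyridin-3-yl cannot be ranked against each other at this place. Of the three groups seen on this carbonyl carbon, only chloromethyl, in compound 3 with 16000 nM, gives a number, and the set now leans further towards entries without one: the limit of > 25000 nM in this assay, at which 3 of the 4 values shown sit.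

On these data alone, how far beyond the limit compound 2 and compound 4 really lie stays open, and with it whether compound 3 differs from either by more than the scatter. Also open, as far as these compounds go, is what a plain methyl, a longer chain, an amine or an unchlorinated pyridin-3-yl at this place would give, so no trend across groups on this carbonyl carbon can yet be drawn.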